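Swapping an Acetyl Ester for a Nitrobenzoate on a Terpenoid

The compounds below may be only part of what the source reports. "The series", "measured", "known", "first", "only" and "open" are said of these compounds alone.

Measured compounds:
compound 1 `CC(=O)OC/C1=C/C[C@](C)(CCC=C(C)C)/C=C/[C@@H](OC(=O)C=C(C)C)[C@](C)(O)/C=C/C1=O`, 2950 nM
compound 2 `C=C1/C=C/C(=O)/C(CO)=C\C[C@](C)(CCC=C(C)C)/C=C/[C@H]1OC(=O)C=C(C)C`, 4300 nM
compound 3 `CC(C)=CCC[C@]1(C)/C=C/[C@@H](OC(=O)C=C(C)C)[C@](C)(O)CCC(=O)/C(CO)=C\C1`, a limit of > 40000 nM

In a functional assay on SMMC-7721 cells (Homo sapiens) for antiproliferative activity, read by MTT assay, with a stated time of 48 h (on this read-out higher numbers stand for weaker inhibition and lower numbers for stronger inhibition), compound 1 gives 2950 nM, the lower of the two numbers shown, while compound 2 gives 4300 nM, and the two lie within the scatter of each other. For compound 3 this assay reports only > 40000 nM, a limit rather than a number. That reading is the limit of > 40000 nM in this assay, at which 1 of the 3 values shown sits.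

Compound 4 `CC(C)=CCC[C@]1(C)/C=C/[C@@H](OC(=O)C=C(C)C)[C@](C)(O)/C=C/C(=O)/C(COC(=O)c2ccc([N+](=O)[O-])cc2)=C\C1` has not yet been tested. It differs from compound 1 in one place: 4-nitrophenyl in place of methyl on a carbonyl carbon. Within the data shown here, no pair of measured compounds shows this change, so no step size can be read from the data. A small step, or none beyond the scatter, is expected. Compound 4 is estimated at 2000 nM, between 500 nM and 9000 nM, so the expected step of a 1.5-fold lower number from compound 1 to compound 4 (0.17 log units; within the scatter) is modest.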

Compound 4, half-maximal inhibitory concentration: 2560 nM
The estimate for compound 4 lay 1.3-fold (0.11 log units) below the measured number, and the stated range covers the measured number.
By their numbers in this assay, from the lowest: compounds 4, 1 and 2 (each within the scatter of the next). At a limit, above all of these: compound 3.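

In this assay, putting 4-nitrophenyl in place of methyl on this carbonyl carbon gives a 1.2-fold lower number from compound 1 to compound 4 (0.06 log units; within the scatter) and so leaves the read-out unchanged within the scatter. The ester on the core of compound 1 therefore accepts a far bulkier group, one carrying an aromatic ring, with no measurable gain or loss.

On these data alone, whether a plain phenyl, a longer chain or a ring bearing an amine or a carboxylic acid would read the same remains open. Nothing shown here accounts for compound 4 and compound 1 reading alike.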